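Swapping Cyclopropyl for Phenyl on the Dichloro Analogue

A few compounds are considered here, and "the series" means these few. Any claim that something is new, unique, unknown or untested is made for them only; others in the source may bear on it.

Three compounds have been measured in an assay on isolated protein for inhibition of Nitric oxide synthase, inducible (Homo sapiens), with a stated time of 30 min, tested at 1 mM; a lower number here means less inhibition, a higher number more inhibition at the concentration tested (going by the name of the read-out):

Compound 1 `Nc1ccc(Cl)cc1C1=NN(C(=O)C2CC2)CC1` gives 18.9%.
Compound 2 `Nc1ccc(Cl)cc1C1=NN(C(=O)c2ccccc2)CC1` gives 17%.
Compound 3 `Nc1cc(Cl)c(Cl)cc1C1=NN(C(=O)C2CC2)CC1` gives 15.5%.

Compound 3 has the smallest of the three numbers, but its gap to compound 2 and its gap to compound 1 both lie within the scatter of repeated measurements, so on these numbers the three compounds cannot be told apart. Compound 3 itself arises from compound 1 by a chloro in place of hydrogen on an aromatic carbon, a step of a number 3.4 percentage points lower from compound 1 to compound 3 (within the scatter).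

Compound 4 `Nc1cc(Cl)c(Cl)cc1C1=NN(C(=O)c2ccccc2)CC1` has not yet been measured. It differs from compound 3 in one place: phenyl in place of cyclopropyl on a carbonyl carbon. The same exchange has already been made once, on the monochloro core, from compound 1 to compound 2, where it gave a number 1.9 percentage points lower from compound 1 to compound 2 (within the scatter). Going by the values given here, that is the only measured step that bears directly on the present one, and it stayed within the scatter.

It is therefore expected that the step from compound 3 to compound 4 in this assay will be a number 1.5 percentage points lower from compound 3 to compound 4 (within the scatter), that is, nothing beyond the scatter. Compound 4 is estimated at 14%, with a range from 5% to 23%.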

Compound 4, a percentage reported as inhibition, at one concentration (the size of the read-out at that concentration, not a potency): 36.1%
Beside the measured number, compound 4's estimate is 22.1 percentage points below it; the measured number lies above the stated range.
By their numbers in this assay, from the lowest: compounds 3, 2 and 1 (each within the scatter of the next); then compound 4.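

In this assay, phenyl in place of cyclopropyl on a carbonyl carbon had looked like a silent change on the monochloro core, but on the core of compound 3 it gives a number 20.6 percentage points higher from compound 3 to compound 4 (beyond the scatter). The added chloro had looked just as silent, yet on the core of compound 2 it gives a number 19.1 percentage points higher from compound 2 to compound 4 (beyond the scatter), so within these four compounds, neither change has one fixed size and the rise appears only when phenyl and the second chloro are present together. The size of the phenyl change therefore depends on the core that carries it, and the chloro change, read the other way round, shows the same dependence: the same change on two cores in this assay, a number 1.9 percentage points lower (within the scatter) from compound 1 to compound 2 and a number 20.6 percentage points higher (beyond the scatter) from compound 3 to compound 4, 22.5 percentage points apart, beyond the scatter of two such steps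

On these data alone, what remains open is whether this rise needs an aromatic ring on the carbonyl carbon, or would also appear with a pyridine ring or a longer chain such as n-butyl, and whether a fluoro or methyl group could stand in for the added chloro. As far as these compounds go, each number in this assay is also a reading at a single concentration, so how potent compound 4 is remains unknown.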